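Fluoro step carried over to the second core

The source may report more compounds than this note shows. Statements on the series, on what has been measured and on what is new or still open speak of the compounds shown alone.

Measured compounds in an assay on CHO cells for agonist activity at Free fatty acid receptor 1 (Homo sapiens), read by FLIPR; a lower number here means that less compound is needed, a higher number that more compound is needed for the effect:
compound 1, `Cc1nc(-c2ccccc2)sc1COc1ccc(OCC(=O)O)c(F)c1`, gives 374 nM
compound 2, `Cc1nc(-c2ccc(F)cc2)sc1COc1ccc(OCC(=O)O)c(F)c1`, gives 112 nM
compound 3, `Cc1nc(-c2ccccc2)sc1COc1ccc(S(=O)(=O)CC(=O)O)cc1`, gives 370 nM

Compound 1 and compound 2 share one core and differ in a single place: fluoro in place of hydrogen on an aromatic carbon. That change alone gave a 3.3-fold lower number from compound 1 to compound 2 (0.52 log units; beyond the scatter). Compound 3 carries a different core; how the core of compound 3 differs from the core of compound 1 is not broken down here. In this assay compound 3 and compound 1 give numbers within the scatter of each other, so nothing separates the two cores on that read-out.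

Compound 4, `Cc1nc(-c2ccc(F)cc2)sc1COc1ccc(S(=O)(=O)CC(=O)O)cc1`, is not yet measured. It differs from compound 3 by fluoro in place of hydrogen on an aromatic carbon. This is the same change as the one from compound 1 to compound 2: what leaves, what enters and the place are described in the same words, and the change occurs twice among the compounds shown. Going by the values given here, only one measured instance of it exists, so any expectation rests on that single step together with the closeness of compound 3 to compound 1 in this assay.

The step from compound 3 to compound 4 is expected to be about a 3.0-fold lower number from compound 3 to compound 4 (0.47 log units; beyond the scatter), matching in size the measured step because that step was a 3.3-fold lower number from compound 1 to compound 2 (0.52 log units; beyond the scatter). Compound 4 is accordingly expected at 125 nM, most likely between 50 nM and 350 nM. The range is kept wide since the transfer of a step from one core to another is supported by a single example.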

Compound 4, half-maximal effective concentration: 253 nM
The estimate for compound 4 lay 2.0-fold (0.31 log units) below the measured number; low and high end bracket the measured number.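

In this assay, the change from phenyl to 4-fluorophenyl on the second core gives a 1.5-fold lower number from compound 3 to compound 4 (0.17 log units; within the scatter), so this pair alone establishes no effect of the fluoro. Set beside the step on the first core, the result gives no evidence that the two cores respond differently: the same change on two cores in this assay, a 3.3-fold lower number (0.52 log units; beyond the scatter) from compound 1 to compound 2 and a 1.5-fold lower number (0.17 log units; within the scatter) from compound 3 to compound 4, 2.3-fold (0.36 log units) apart, within the scatter of two such steps. The series therefore shows that the step measured on the first core is compatible with the result on the second, but not that it carries over reliably or at the same size, and two pairs cannot settle whether the core alters it.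

The compounds shown leave open whether chloro, methoxy or trifluoromethyl at the same place on the phenyl would behave alike on the two cores, since fluoro is the only group tested there. They also leave open whether the comparison would hold with a tetrazole in place of the carboxylic acid, or on any core beyond these two.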